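This account rests on a few compounds, and the source may have more. Where it says the series, first, only, none or still open, it means among the compounds named here.

Compound 1 `O=C(NO)c1ccc(/C=C/c2ccnc(-c3cc(F)ccc3O)c2)cc1` gives 1920 nM. Compound 2 `O=C(NO)c1ccc(/C=C/c2ccnc(-c3ccccc3O)c2)cc1` gives 1420 nM. Compound 3 `Cc1ccc(-c2cncc(/C=C/c3ccc(C(=O)NO)cc3)c2)cc1` gives > 10000 nM, which is a limit of the assay and not a number.

The three compounds were tested in a functional assay on MGC-803 cells (Homo sapiens) for antiproliferative activity, read by CellTiter-Glo, with a stated time of 72 h; a higher number here means a weaker inhibitor, a lower number a stronger inhibitor. Compound 2 and compound 1 share one core and differ in one place: fluoro in place of hydrogen on an aromatic carbon. That change gave a 1.4-fold higher number from compound 2 to compound 1 (0.13 log units; within the scatter), so the two values are not told apart. Compound 3 sits on a different core; how its core differs from that of compound 2 is not broken down here. For compound 3 only a limit is known, at the limit of > 10000 nM in this assay, at which 1 of the 3 values shown sits.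

Compound 4 `Cc1ccc(-c2cncc(/C=C/c3ccc(C(=O)NO)cc3)c2)c(F)c1` has not yet been measured. It differs from compound 3 by fluoro in place of hydrogen on an aromatic carbon. For the measured compounds named here, this is the same kind of change as the one from compound 2 to compound 1, not the same change: in compound 1 the fluoro sits meta to a large group and para to a hydroxy group, while in compound 4 it sits ortho to a large group and meta to a methyl group. Resting on the step of a 1.4-fold higher number from compound 2 to compound 1 (0.13 log units; within the scatter), the expected step from compound 3 to compound 4 is a step that the limit leaves unreadable from compound 3 to compound 4, a small one, and since compound 3 itself reports a limit at the limit of > 10000 nM in this assay, at which 1 of the 3 values shown sits, compound 4 is expected to sit near or beyond that limit as well. The estimate for compound 4 in this assay is 12000 nM, with a range from 4000 nM to 40000 nM.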

Compound 4, half-maximal inhibitory concentration: 2240 nM
Estimate against measurement, compound 4: 5.4-fold (0.73 log units) above; measured number below the stated range.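

In this assay, fluoro in place of hydrogen on an aromatic carbon gave an at least 4.4-fold lower number from compound 3 to compound 4 (0.64 log units; beyond the scatter), so this change did not carry over from one core to the other as a step of one size: the same change on two cores in this assay, a 1.4-fold higher number (0.13 log units; within the scatter) from compound 2 to compound 1 and an at least 4.4-fold lower number (0.64 log units; beyond the scatter) from compound 3 to compound 4, at least 6.0-fold (0.78 log units) apart, beyond the scatter of two such steps

Compound 3 stands at > 10000 nM, which is a limit of the assay and not a number, so the step to compound 4 has a known minimum size but no known full size. For the compounds shown here, the comparison rests on only two pairs, which differ both in their core and in the surroundings of the fluoro, with the fluoro of compound 4 ortho to a large group and meta to a methyl group, so it does not show which of these separates the two steps.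

From the compounds shown here alone, it remains open whether fluoro at another place on the 4-methylphenyl group of compound 3 would give a comparable step, and whether chloro or methoxy in place of the fluoro of compound 4 would do the same. Going by these compounds, it is also open how a hydroxy group on the outer ring would behave on the core of compound 3, and whether an amine there would change the number in either core.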